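Compound 4 as the mirror image of compound 3

This account rests on a few compounds, and the source may have more. Where it says the series, first, only, none or still open, it means among the compounds named here.

Values in a functional assay on HCT-116 cells (Homo sapiens) for inhibition, read by MTT assay, with a stated time of 72 h (a higher number here means a weaker inhibitor, a lower number a stronger inhibitor), are as follows
- compound 1 `CC1=NN(c2ccccc2)C(=O)[C@@]12C(=O)C=CC[C@@H]2c1cccc(C)c1` gives 3800 nM
- compound 2 `COc1ccccc1[C@H]1CC=CC(=O)[C@@]12C(=O)N(c1ccccc1)N=C2C` gives 13900 nM
- compound 3 `CC1=NN(c2ccccc2)C(=O)[C@]12C(=O)C=CC[C@H]2c1ccccc1` gives 5300 nM

Compound 3 stands second highest of the three, within the scatter of compound 1 and beyond it from compound 2. Compound 4 `CC1=NN(c2ccccc2)C(=O)[C@@]12C(=O)C=CC[C@@H]2c1ccccc1` differs from compound 3 only in configuration as drawn (the two compounds have the same atoms and bonds and differ only in configuration as drawn: 2 of 2 stereo elements differ (all stereocentres are inverted: mirror images); a stereocentre at a saturated ring carbon is drawn S in compound 3 and R in compound 4; a stereocentre at a saturated ring carbon is drawn S in compound 3 and R in compound 4), so the two are mirror images. For the measured compounds named here, the one measured step (a 3.7-fold higher number from compound 1 to compound 2 (0.56 log units; beyond the scatter)) is modest but exchanges a group, 2-methoxyphenyl in place of 3-methylphenyl, and inverts nothing. Going by the values given here, it therefore bears only indirectly, and no mirror-image pair has been measured. No direction is favoured, and the expected step (a 1.2-fold lower number from compound 3 to compound 4 (0.07 log units; within the scatter)) is none beyond the scatter. Compound 4 is estimated at 4500 nM (range 1800 nM to 12000 nM).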

Compound 4, half-maximal inhibitory concentration: 6070 nM
The estimate for compound 4 lay 1.3-fold (0.13 log units) below the measured number, and the stated range covers the measured number.
By their numbers in this assay, from the lowest: compounds 1, 3 and 4 (each within the scatter of the next); then compound 2.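

In this assay, inverting both stereocentres gives a 1.1-fold higher number from compound 3 to compound 4 (0.06 log units; within the scatter), so this assay does not separate the mirror-image pair: the fact that compounds 3 and 4 differ only in the configuration as drawn On the aromatic ring, hydrogen in place of methoxy gives a 2.3-fold lower number from compound 2 to compound 4 (0.36 log units; beyond the scatter), a modest step beyond the scatter, whereas hydrogen in place of methyl gives a 1.6-fold higher number from compound 1 to compound 4 (0.20 log units; within the scatter). Among these aromatic changes, only the methoxy step stands clear of the scatter.

Open, on these data alone, is whether an amine or a carboxylic acid on that aromatic carbon would give a step beyond the scatter. Also open, as far as these compounds go, is whether the mirror images of compound 1 and compound 2 would stay within the scatter of their partners.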